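A few compounds are considered here, and "the series" means these few. Any claim that something is new, unique, unknown or untested is made for them only; others in the source may bear on it.

Measured so far in a toxicity assay on J774.A1 cells (Mus musculus) for cytotoxicity, read by SYBR Green assay, with a stated time of 1 h; a higher number here means that more compound is needed for the effect, a lower number that less compound is needed
- compound 1 (`CN(C)c1ccc2cc(-c3ccccc3Cl)c(N)nc2c1`) gives 2400 nM
- compound 2 (`CN(C)c1ccc2cc(-c3cccc(Cl)c3)c(N)nc2c1`) gives 13000 nM
- compound 3 (`CN(C)c1ccc2cc(-c3ccc(Cl)cc3)c(N)nc2c1`) gives 2900 nM

Compound 3 sits within the scatter of compound 1, and its one clear gap is to the remaining compound (a 4.5-fold lower number from compound 2 to compound 3 (0.65 log units; beyond the scatter)). Compound 4 (`CN(C)c1ccc2cc(-c3ccc(Cl)cc3Cl)c(N)nc2c1`) has chloro in place of hydrogen on an aromatic carbon, ortho to a large group and meta to a chloro group (chloro in place of hydrogen on an aromatic carbon). It thus keeps the chloro placement of compound 3 and adds that of compound 1. Those two placements hardly differ (a 1.2-fold higher number from compound 1 to compound 3 (0.08 log units; within the scatter)). Only the third placement moved the number (a 5.4-fold higher number from compound 1 to compound 2 (0.73 log units; beyond the scatter)), and compound 4 lacks it. Among the compounds with values here, no measured step adds a second chloro, so the evidence is indirect. The expected change stays within the scatter (a 1.5-fold lower number from compound 3 to compound 4 (0.16 log units; within the scatter)). For compound 4 the estimate is 2000 nM, with an expected range of 800 nM to 5000 nM.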

Compound 4, half-maximal effective concentration: 8700 nM
Beside the measured number, compound 4's estimate is 4.4-fold (0.64 log units) below it, and the stated range ends below it.
By their numbers in this assay, from the lowest: compounds 1 and 3 (each within the scatter of the next); then compounds 4 and 2 (each within the scatter of the next).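

A second chloro on the ring clearly changes the number, whichever single-chloro compound it is added to: a 3.0-fold higher number from compound 3 to compound 4 (0.48 log units; beyond the scatter), and a 3.6-fold higher number from compound 1 to compound 4 (0.56 log units; beyond the scatter). Two placements that are within the scatter of each other when alone therefore do not simply carry over when combined, as more compound is needed for the effect with both present. Nothing available here explains this shift.

As far as these compounds go, whether a fluoro or a methoxy group at this same place would bring a similar rise stays open. From the compounds shown here alone, it is also open whether a second chloro would move the number of compound 2.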